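Series notes: from compound 3 to compound 4

A few compounds are considered here, and "the series" means these few. Any claim that something is new, unique, unknown or untested is made for them only; others in the source may bear on it.

The set comprises compound 1 `CCC1(CCCCN2CCN(c3ccc(OC)cc3)CC2)C(=O)Nc2ccccc21`, compound 2 `O=C1Nc2ccccc2C1CCCCN1CCN(c2cccc(Cl)c2)CC1`, compound 3 `CCC1(CCCCN2CCN(c3ccc(Cl)cc3)CC2)C(=O)Nc2ccccc21` and the not yet measured compound 4 `CCC1(CCCCN2CCN(c3cccc(Cl)c3)CC2)C(=O)Nc2ccccc21`. In a functional assay on the whole organism (strain NMRI) with Mus musculus as the target, with a stated time of 5 min (a lower number here means that less compound is needed, a higher number that more compound is needed for the effect), compound 3 gives only a limit, > 10 mg/kg. Compound 2 likewise reaches only a limit in this assay, > 10 mg/kg. For compound 1 no result in this assay is reported, "not determined" (no result reported). Compound 3 thus stands at the limit of > 10 mg/kg in this assay, at which 2 of the 3 values shown sit, with no single number to rank it. The change toward compound 4 is 3-chlorophenyl in place of 4-chlorophenyl on an amine nitrogen in a ring. Because compound 2, which also carries the 3-chlorophenyl, sits at the limit > 10 mg/kg, no step beyond the scatter is expected. Compound 4 is expected at 15 mg/kg (5 mg/kg to 40 mg/kg), an expected step that the limit leaves unreadable from compound 3 to compound 4.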

Compound 4, minimum effective dose: > 10 mg/kg
Compound 4: only a limit was reported; the forecaster's own chance of this, stated with the estimate: 70%; the middle value is on the limit's open side.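

In this assay, going by these compounds alone, compound 4 gives only a limit, > 10 mg/kg, so no step from compound 2 or compound 3 to compound 4 can be read. The compounds shown leave open whether 3-chlorophenyl in place of 4-chlorophenyl, or ethyl in place of hydrogen, changes the minimum effective dose at all.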